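This account rests on a few compounds, and the source may have more. Where it says the series, first, only, none or still open, it means among the compounds named here.

Measured so far:
compound 1, `CCN(CCn1ccc(-c2ccc(F)cn2)n1)C(=O)c1cc(F)ccc1-n1nccn1`: 11.4 nM
compound 2, `CCN(CCn1ccc(-c2ccc(F)cn2)n1)C(=O)c1cc(Cl)ccc1-n1nccn1`: 2.82 nM

In a functional assay on CHO cells for antagonist activity at Orexin receptor type 2 (Homo sapiens), read by fluorescence and calcium flux, with a stated time of 30 min (on this read-out higher numbers stand for weaker inhibition and lower numbers for stronger inhibition), compound 2 gives the lower of the two numbers recorded. For the measured compounds named here, the only step that bears on the next change is the one already measured: a 4.0-fold lower number from compound 1 to compound 2 (0.61 log units; beyond the scatter). That step lies beyond the scatter, so a halogen exchange at this position has moved the read-out to a degree that counts.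

Compound 3, `CCN(CCn1ccc(-c2ccc(F)cn2)n1)C(=O)c1cc(OC)ccc1-n1nccn1`, has not yet been measured in this assay. It differs from compound 2 in one place: methoxy in place of chloro on an aromatic carbon. Going by the values given here, no measured pair shows a methoxy at this position, so the one step known gives only a rough guide, and its direction for a methoxy is not fixed by it. Compound 3 is therefore expected to show a 1.8-fold higher number from compound 2 to compound 3 (0.25 log units; within the scatter), a shift that would remain close to the scatter. The estimate for compound 3 in this assay is 5 nM, with a likely range from 1.5 nM to 20 nM.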

Compound 3, antagonist equilibrium constant: 638 nM
For compound 3 the middle estimate is 130-fold (2.11 log units) below the measured one; measured number outside the range, above it.
By their numbers in this assay, from the lowest: compound 2; then compound 1; then compound 3.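

In this assay, this position, para to the 2H-1,2,3-triazol-2-yl group, turns out to respond far more strongly than the halogen exchange alone indicated: methoxy in place of chloro gives a 230-fold higher number from compound 2 to compound 3 (2.35 log units; beyond the scatter). The loss is not tied to the chloro compound, since methoxy in place of fluoro gives a 56-fold higher number from compound 1 to compound 3 (1.75 log units; beyond the scatter), so both halogens stand well apart from methoxy on this read-out. Nothing available explains why this change costs so much.

The compounds shown leave open whether a methyl, a hydroxy or a trifluoromethyl group at this position would stay close to the halogens or fall with the methoxy. They also leave open whether a bromo group would extend the gain seen from fluoro to chloro.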